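The source may report more compounds than this note shows. Statements on the series, on what has been measured and on what is new or still open speak of the compounds shown alone.

Compound 1 `C=C(C=O)CC[C@@H]1C(=C)C[C@@H](OC(=O)c2ccccc2)[C@@H]2[C@]1(C)CCC[C@@]2(C)C(=O)O` and compound 2 `C=C1C[C@@H](OC(=O)c2ccccc2)[C@@H]2[C@](C)(CCC[C@@]2(C)C(=O)O)[C@@H]1CC/C(C)=C/CO` share a core and differ only at the side chain. In an assay on isolated protein for inhibition of beta-glucuronidase (Bos taurus) (on this read-out higher numbers stand for weaker inhibition and lower numbers for stronger inhibition), compound 1 gives 10000 nM, and in this assay compound 2 gives 6800 nM; the step of a 1.5-fold lower number from compound 1 to compound 2 (0.17 log units; within the scatter) stays within the scatter, so compound 2 stands level with compound 1 and there is no order between them. Compound 3 `C=C1C[C@@H](OC(=O)c2ccccc2)[C@@H]2[C@](C)(CCC[C@@]2(C)C(=O)O)[C@@H]1CCC(C)=O` alters the same side chain again: acetyl in place of 3-hydroxy-1-methylprop-1-en-1-yl on a saturated chain carbon, two bonds along the chain from a saturated ring carbon. Among the measured compounds shown here, the only measured step at this place, from compound 1 to compound 2, exchanged one small chain group for another without a shift beyond the scatter, so a further exchange there gives no basis to expect a large move in either direction in this assay. Compound 3 is therefore expected to sit close to compound 2, with the estimated step of a 1.2-fold higher number from compound 2 to compound 3 (0.07 log units; within the scatter). The estimate for compound 3 is 8000 nM, within a range from 3000 nM to 25000 nM.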

Compound 3, half-maximal inhibitory concentration: > 100000 nM
Compound 3: a limit, no number; the forecaster's own chance of this, stated with the estimate: 15%; middle value at least 12-fold (1.09 log units) away from the limit.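

This place on the side chain proved sensitive to what it carries, which the earlier pair, level with each other, had not shown: acetyl in place of 3-hydroxy-1-methylprop-1-en-1-yl gives an at least 14-fold higher number from compound 2 to compound 3 (1.16 log units; beyond the scatter), and acetyl in place of 1-formylethenyl gives an at least 10-fold higher number from compound 1 to compound 3 (1.00 log units; beyond the scatter). In this assay compound 3 gives > 100000 nM, which is a limit of the assay and not a number: the limit of > 100000 nM in this assay, at which 1 of the 3 values shown sits. Of the three groups shown at this place, only acetyl is separated from the others by a step beyond the scatter.

The change to acetyl removes the hydroxyl and shortens the group in a single step, and the compounds shown do not tell these two changes apart. They also leave open how an amine, a carboxylic acid or a longer chain ending in a ketone would read at this place.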